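Cyano to isopropyl on the urea aryl ring

A few compounds are considered here, and "the series" means these few. Any claim that something is new, unique, unknown or untested is made for them only; others in the source may bear on it.

Measured compounds:
compound 1, `O=C(CC1CCCCCC1)N1CCC(c2nc(-c3ccc4ccccc4n3)no2)CC1`, 840 nM
compound 2, `N#Cc1ccccc1NC(=O)N1CCC(c2nc(-c3ccc4ccccc4n3)no2)CC1`, 190 nM
compound 3, `COc1ccccc1NC(=O)N1CCC(c2noc(-c3ccc4ccccc4n3)n2)CC1`, 2400 nM

In a functional assay on Shh Light II cells (Mus musculus) for inhibition, read by a luciferase reporter (a lower number here means a stronger inhibitor, a higher number a weaker inhibitor), compound 2 gives 190 nM, the lowest of the three numbers. Compound 1 gives 840 nM, and compound 3, which carries a methoxy on the aryl ring of the urea and a differently arranged core, gives 2400 nM. For the measured compounds named here, the only single-point step among the measured compounds is a 4.4-fold lower number from compound 1 to compound 2 (0.65 log units; beyond the scatter), which compares an alkyl amide with an aryl urea and says nothing about what sits on the aryl ring.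

Compound 4, `CC(C)c1ccccc1NC(=O)N1CCC(c2nc(-c3ccc4ccccc4n3)no2)CC1`, differs from compound 2 by isopropyl in place of cyano on an aromatic carbon. Going by the values given here, no measured step bears on this change; compound 3 is the only other aryl urea, and its core differs as well, so its higher number cannot be read as the effect of the aryl group alone. With the urea and the core of compound 2 kept, compound 4 is expected to stay near compound 2, with at most a modest rise, a 2.1-fold higher number from compound 2 to compound 4 (0.32 log units; beyond the scatter). Compound 4 is therefore estimated at 400 nM, within 120 nM to 1500 nM.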

Compound 4, half-maximal inhibitory concentration: 480 nM
Estimate against measurement, compound 4: 1.2-fold (0.08 log units) below; low and high end bracket the measured number.
By their numbers in this assay, from the lowest: compound 2; then compounds 4 and 1 (each within the scatter of the next); then compound 3.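

In this assay, isopropyl in place of cyano on the aromatic carbon gives a 2.5-fold higher number from compound 2 to compound 4 (0.40 log units; beyond the scatter). For the compounds shown here, this is the first step here that reads a change on the aryl ring of the urea itself, and it shows that this position accepts isopropyl at only a modest cost. The other new step, a 1.8-fold lower number from compound 1 to compound 4 (0.24 log units; within the scatter), shows that an aryl urea does not by itself separate from the cycloheptylmethyl amide, since the step beyond the scatter, a 4.4-fold lower number from compound 1 to compound 2 (0.65 log units; beyond the scatter), appears only with cyano on the ring, and nothing measured here accounts for this difference.

Going by these compounds, whether a methyl group or a chlorine at this position would stay with cyano or with isopropyl remains open. So does how methoxy on this ring would read on the core of compound 2.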